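Pyrazolyl chalcones: third methoxy on the carbonyl aryl

The compounds below may be only part of what the source reports. "The series", "measured", "known", "first", "only" and "open" are said of these compounds alone.

Measured compounds:
compound 1 `COc1cc(-c2cc(/C=C/C(=O)c3ccc(Cl)c(Cl)c3)[nH]n2)cc(OC)c1OC`: 96000 nM
compound 2 `COc1ccc(-c2cc(/C=C/C(=O)c3cc(OC)c(OC)c(OC)c3)[nH]n2)cc1OC`: > 100000 nM
compound 3 `COc1ccc(C(=O)/C=C/c2cc(-c3cc(OC)c(OC)c(OC)c3)n[nH]2)cc1OC`: > 100000 nM

In a functional assay on SR cells (Homo sapiens) for inhibition, read by sulforhodamine B assay, with a stated time of 48 h (on this read-out lower numbers stand for higher toxicity in this test and higher numbers for lower toxicity in this test), compound 1 gives 96000 nM. Compound 2 reaches only the limit of the test, > 100000 nM. Compound 3 also returns only a limit, > 100000 nM. Compound 3 thus stands at the top of the series, where (the limit of > 100000 nM in this assay, at which 2 of the 3 values shown sit). Within the data shown here, the one measured step, an at least 1.0-fold higher number from compound 1 to compound 3 (0.01 log units; that floor lies within the scatter), sits at the floor of that limit and within the scatter.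

Compound 4 `COc1cc(C(=O)/C=C/c2cc(-c3cc(OC)c(OC)c(OC)c3)n[nH]2)cc(OC)c1OC` differs from compound 3 by methoxy in place of hydrogen on an aromatic carbon. Among the measured compounds shown here, no measured step covers such an addition; the measured step concerns an aryl swap only. With compound 3 at the limit, the expected step of a number no higher from compound 3 to compound 4 (the limit leaves the size open) is none beyond the scatter, and compound 4 is estimated at 100000 nM, between 50000 nM and 200000 nM, most likely again as a limit.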

Compound 4, concentration lethal to 50% of the cells: > 100000 nM
Compound 4 ended at the assay's limit; the forecaster's own chance of this, stated with the estimate: 70%; the middle value sits exactly at the limit.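

Compound 2, compound 3 and compound 4 all sit at a limit of the test, so the steps to compound 4 cannot be read. On these data alone, whether methoxy in place of hydrogen on an aromatic carbon shifts the number in this assay stays open.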